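The source may hold more compounds than are shown below. What is called first, only, known or untested is meant among the compounds shown, and "the series" means these compounds.

Compound 1, `C=CC1=C(C(=O)NC(C)(C)C)C(c2ccc(OC)cc2)OC1`, in a functional assay on A549 cells (Homo sapiens) for cytotoxicity, read by MTT assay, with a stated time of 24 h (on this read-out higher numbers stand for weaker inhibition and lower numbers for stronger inhibition), gives a limit of the assay, > 100000 nM.
Compound 2, `C=CC1=C(C(=O)NCCCCC)C(c2ccc(OC)cc2)OC1`, in this assay gives 36500 nM.

Among the compounds with values here, compound 2 holds the only plain number among the two measured compounds; the value of compound 1 is a limit, not a number, as the line the limit of > 100000 nM in this assay, at which 1 of the 2 values shown sits, states. Within the data shown here, the one step that can be read is an at least 2.7-fold lower number from compound 1 to compound 2 (0.43 log units; beyond the scatter), which places compound 2 at a lower number than the limit left by compound 1.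

Compound 3, `C=CC1=C(C(=O)NCC(C)C)C(c2ccc(OC)cc2)OC1`, differs from compound 2 in a single place: isopropyl in place of butyl on a saturated chain carbon bound to an amide-type nitrogen. Among the measured compounds shown here, the only measured step that bears on this change is the one from compound 1 to compound 2, where pentyl replaced tert-butyl on the amide-type nitrogen and the number fell at least modestly. The move from pentyl to isobutyl reverses part of that path, so an at least modest rise in the number is expected in this assay, though the size of the earlier step is known only as a lower bound and the new amide substituent is neither of the two already measured. Compound 3 is therefore expected to give 65000 nM, within 25000 nM to 170000 nM, which means an estimated step of a 1.8-fold higher number from compound 2 to compound 3 (0.25 log units; within the scatter).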

Compound 3, half-maximal inhibitory concentration: > 100000 nM
Compound 3: no number, only a limit; the forecaster's own chance of this, stated with the estimate: 35%; middle value at least 1.5-fold (0.18 log units) away from the limit.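

In this assay, compound 1 alone could not show whether only tert-butyl on the amide-type nitrogen left the cells without a measurable number, and the change on the saturated chain carbon bound to an amide-type nitrogen now shows that a smaller alteration has the same outcome, with isopropyl in place of butyl giving an at least 2.7-fold higher number from compound 2 to compound 3 (0.43 log units; beyond the scatter). Among the three amides, the unbranched pentyl of compound 2 is therefore the only substituent with a plain number, while the branched tert-butyl and isobutyl substituents share one limit: the limit of > 100000 nM in this assay, at which 2 of the 3 values shown sit. The step between compound 1 and compound 3 cannot be read, as both of their values are limits.

The compounds shown leave open whether the straight chain itself matters, as a shorter propyl or a longer octyl chain on the amide-type nitrogen could show how the number moves from the 36500 nM of compound 2. They also leave open whether a pentyl chain carrying an amine or a carboxylic acid would keep a plain number in this assay.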